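Methyl gives way to furan-2-yl on a carbonyl carbon

The source may hold more compounds than are shown below. What is called first, only, known or untested is meant among the compounds shown, and "the series" means these compounds.

In a functional assay on KB cells (Homo sapiens) for cytotoxicity (on this read-out lower numbers stand for stronger inhibition and higher numbers for weaker inhibition), compound 3 (`COc1ccc(S(=O)(=O)N2CCc3cccc(NC(C)=O)c32)cc1`) gives 89 nM and so sits level with compound 2 (`COc1ccc(S(=O)(=O)N2CCc3cccc(NC(=O)c4ccc(F)cc4)c32)cc1`) at 93 nM on this read-out. Both stand well clear of compound 1 (`COc1ccc(S(=O)(=O)N2CCc3cccc(NS(=O)(=O)c4ccc(F)cc4)c32)cc1`) with its 1200 nM on the weak side.

The change under consideration leads from compound 3 to compound 4 (`COc1ccc(S(=O)(=O)N2CCc3cccc(NC(=O)c4ccco4)c32)cc1`) and reads furan-2-yl in place of methyl on a carbonyl carbon in the count of atoms. In words, it is furan-2-yl in place of methyl on a carbonyl carbon, turning acetamido into ((furan-2-yl)carbonyl)amino.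

The closest measured change is a 1.0-fold lower number from compound 2 to compound 3 (0.02 log units; within the scatter) for methyl in place of 4-fluorophenyl on a carbonyl carbon, and it stays within the scatter. The large steps of a 13-fold lower number from compound 1 to compound 2 (1.11 log units; beyond the scatter) and a 13-fold lower number from compound 1 to compound 3 (1.13 log units; beyond the scatter) both remove a (4-fluorophenyl)sulfonyl on a nitrogen on an aromatic ring, a replacement that compound 4 does not repeat, so they bear on it only weakly. No furan-2-yl has yet been read on this carbonyl, which leaves real uncertainty. The estimated step is a 1.0-fold lower number from compound 3 to compound 4 (0.02 log units; within the scatter) and none beyond the scatter is expected. For compound 4 the estimated value is 85 nM with 30 nM to 240 nM as the expected range.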

Compound 4, half-maximal inhibitory concentration: 9.6 nM
The estimate for compound 4 lay 8.9-fold (0.95 log units) above the measured number; the whole stated range lies above it.
By their numbers in this assay, from the lowest: compound 4; then compounds 3 and 2 (each within the scatter of the next); then compound 1.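

In this assay the carbonyl carbon proves sensitive to what it carries, which the level reading of methyl and 4-fluorophenyl had not revealed: the step is a 9.3-fold lower number from compound 3 to compound 4 (0.97 log units; beyond the scatter) for furan-2-yl in place of methyl, and a 9.7-fold lower number from compound 2 to compound 4 (0.99 log units; beyond the scatter) for furan-2-yl in place of 4-fluorophenyl. The gain over the sulfonamide also grows, with (furan-2-yl)carbonyl in place of (4-fluorophenyl)sulfonyl on the nitrogen giving a 130-fold lower number from compound 1 to compound 4 (2.10 log units; beyond the scatter) and so going further than either earlier replacement of that sulfonyl group. Nothing available explains why furan-2-yl stands apart from methyl and 4-fluorophenyl on this carbonyl.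

The compounds shown leave open whether the gain depends on the ring oxygen, its placing or the five-membered aromatic ring as such, a question that thiophen-2-yl, furan-3-yl or pyrrol-2-yl on the same carbonyl would address. They also do not show how far the position tolerates other kinds of group, such as a cyclopropyl ring, a dimethylamino group or a longer alkyl chain.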